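This account rests on a few compounds, and the source may have more. Where it says the series, first, only, none or still open, it means among the compounds named here.

Compound 2 `CN(C)CCCOc1ccc(NC(=O)c2cccc(-c3cccc(O)c3)c2)cc1F` is one of two analogues measured in a functional assay on SMMC-7721 cells (Homo sapiens) for antiproliferative activity, read by MTT assay, with a stated time of 48 h; a higher number here means a weaker inhibitor, a lower number a stronger inhibitor. Compound 2 gives 11600 nM, the highest of the two numbers. Its nearest neighbour is compound 1 `CN(C)CCCOc1ccc(NC(=O)c2cccc(-c3cccc(O)c3)c2)cc1`, which differs only in bearing hydrogen where compound 2 carries fluoro; in this assay compound 1 gives 9280 nM. Among the compounds with values here, the step of a 1.3-fold higher number from compound 1 to compound 2 (0.10 log units; within the scatter) is the only measured step available and lies within the scatter, so the two compounds cannot be separated on these numbers.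

Compound 3 `CN(C)CCCOc1ccc(NC(=O)c2cccc(-c3cccc(O)c3)c2)cc1Cl` has not been measured in this assay. It differs from compound 2 by chloro in place of fluoro on an aromatic carbon, the position being ortho to a 3-(dimethylamino)propoxy group and meta to a large group. Within the data shown here, the only step that bears on this change is the one from compound 1 to compound 2, where introducing fluoro at this same position moved the number by no more than the scatter. With one halogen replacing another at that position, and no larger step recorded among these compounds, no shift beyond the scatter is expected for compound 3. The step of a 1.1-fold lower number from compound 2 to compound 3 (0.02 log units; within the scatter) is therefore expected to be small. Compound 3 is estimated at 11000 nM, with a range from 5000 nM to 25000 nM.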

Compound 3, half-maximal inhibitory concentration: 1010000 nM
For compound 3 the middle estimate is 92-fold (1.96 log units) below the measured one, and the stated range ends below it.
By their numbers in this assay, from the lowest: compounds 1 and 2 (each within the scatter of the next); then compound 3.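

In this assay, the earlier pair showed only that fluoro ortho to a 3-(dimethylamino)propoxy group could stand in for hydrogen without a change beyond the scatter, and this position now proves far from indifferent to what it carries: chloro in place of fluoro gives an 87-fold higher number from compound 2 to compound 3 (1.94 log units; beyond the scatter). Chloro in place of hydrogen at the same carbon gives a 110-fold higher number from compound 1 to compound 3 (2.04 log units; beyond the scatter), so the large step holds against both neighbours and marks compound 3 as the outlier of the three. Fluoro and chloro match in heavy-atom count and in hydrogen-bond donors and acceptors, so these counts do not separate the two groups, and a swap of one halogen for another on this ring cannot be assumed to be neutral here.

No available evidence accounts for the size of this step. On these data alone, whether bromo, methyl or methoxy at this position would stay with hydrogen and fluoro or fall with chloro remains open, as does whether chloro would give a step of this size on a core without the 3-(dimethylamino)propoxy group.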